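A Methyl Added to a Growth-Inhibiting Chain

A few compounds are considered here, and "the series" means these few. Any claim that something is new, unique, unknown or untested is made for them only; others in the source may bear on it.

compound 1 `CC1=C(CCC(=O)OCCCCOc2no[n+]([O-])c2S(=O)(=O)c2ccccc2)C(=O)c2c(O)cccc2C1=O`: 97.6%
compound 2 `CC1=C(CCC(=O)OCCOc2no[n+]([O-])c2S(=O)(=O)c2ccccc2)C(=O)c2c(O)cccc2C1=O`: 97.6%

In a functional assay on MDA-MB-231 cells (Homo sapiens) for inhibition, read by MTT assay, with a stated time of 72 h, tested at 10 uM (on this read-out higher numbers stand for more inhibition of growth at the one concentration tested and lower numbers for less inhibition of growth), compound 1 and compound 2 stand level at the digits shown, and the small difference in their linking chains leaves the read-out unchanged within the usual scatter. Compound 3 `CC1=C(C(C)CC(=O)OCCCCOc2no[n+]([O-])c2S(=O)(=O)c2ccccc2)C(=O)c2c(O)cccc2C1=O` differs from compound 1 by methyl in place of hydrogen on a saturated chain carbon bound to a double-bonded ring carbon and a saturated chain carbon. For the measured compounds named here, no measured pair shows what such a single change does here, so the step from compound 1 to compound 3 is expected to be a number 2.6 percentage points lower from compound 1 to compound 3 (within the scatter), no change beyond the scatter. Compound 3 is estimated to reach 95%, within a range from 85% to 100%.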

Compound 3, percent growth inhibition at one concentration: 92.7%
Compound 3: middle estimate off by 2.3 percentage points, on the high side; the measured number falls inside the stated range.
By their numbers in this assay, from the lowest: compounds 3, 1 and 2 (each within the scatter of the next).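

In this assay, methyl in place of hydrogen on a saturated chain carbon bound to a double-bonded ring carbon and a saturated chain carbon gives a number 4.9 percentage points lower from compound 1 to compound 3 (within the scatter). For the compounds shown here, this position therefore accepts the added methyl without a change beyond the scatter, which the earlier compounds could not show. No measurement on hand offers an explanation for this result. As far as these compounds go, whether a larger or different group at this carbon, such as an ethyl, a hydroxyl or an amine, would also leave the read-out in place remains open. A single tested concentration also leaves open whether compound 1 and compound 3 would separate at lower concentrations.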